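Cytotoxicity series: pentyl, 4-ethylphenyl, 4-isopropylphenyl on the shared core

A few compounds are considered here, and "the series" means these few. Any claim that something is new, unique, unknown or untested is made for them only; others in the source may bear on it.

Compound 1 `CCCCCc1cc(-c2cn([C@H]3C[C@H](OC(C)=O)[C@@H](COC(C)=O)O3)c(=O)[nH]c2=O)on1` gives 3000 nM in an ADME assay on MT4 cells (Homo sapiens) for cytotoxicity; a higher number here means that more compound is tolerated, a lower number that less compound is tolerated. Compound 2 `CCc1ccc(-c2cc(-c3cn([C@H]4C[C@H](OC(C)=O)[C@@H](COC(C)=O)O4)c(=O)[nH]c3=O)on2)cc1` gives 3000 nM, so the step of no change at the digits printed from compound 1 to compound 2 (within the scatter) stays within the scatter, and compound 2 stands level with compound 1. Compound 3 `CC(=O)OC[C@H]1O[C@@H](n2cc(-c3cc(-c4ccc(C(C)C)cc4)no3)c(=O)[nH]c2=O)C[C@@H]1OC(C)=O` carries the change (methyl in place of hydrogen on a saturated chain carbon bound to an aromatic carbon and a saturated chain carbon). Among the compounds with values here, the only step measured so far, from pentyl to 4-ethylphenyl, left this assay unchanged, and a single methyl is a smaller alteration than that, so no step beyond the scatter is expected for no change at the digits printed from compound 2 to compound 3 (within the scatter). Compound 3 is therefore estimated at 3000 nM, between 1500 nM and 6000 nM.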

Compound 3, half-maximal cytotoxic concentration: 3000 nM
The estimate for compound 3 equals the measured number at the digits printed; the measured number falls inside the stated range.
By their numbers in this assay, from the lowest: compounds 1, 2 and 3 (each within the scatter of the next).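

In this assay, extending 4-ethylphenyl to 4-isopropylphenyl by a methyl on the saturated chain carbon brings no change at the digits printed from compound 2 to compound 3 (within the scatter), so this branching leaves the read-out unmoved. Replacing pentyl with 4-isopropylphenyl on the aromatic carbon likewise brings no change at the digits printed from compound 1 to compound 3 (within the scatter), and the three groups cannot be separated here. No supporting measurement bears on this result.

Still open, as far as these compounds go, is whether an amine or a carboxylic acid on the aromatic carbon that carries these groups would move this assay beyond the scatter.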